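A few compounds are considered here, and "the series" means these few. Any claim that something is new, unique, unknown or untested is made for them only; others in the source may bear on it.

Measured in a functional assay on a cell-free system (plasma, Homo sapiens) for inhibition, with Plasma (Rattus norvegicus) as the target; a higher number here means a weaker inhibitor, a lower number a stronger inhibitor:
- compound 1 `COc1ccc(C(CC(=O)O)NC(=O)c2cccc(C(=O)Nc3ccc4c(c3)CNCC4)c2)cc1` gives 17 nM
- compound 2 `COc1ccc(C(CC(=O)O)NC(=O)c2cccc(C(=O)Nc3ccc4c(c3)CNCC4)c2)cc1OC` gives 11.6 nM
- compound 3 `O=C(O)CC(NC(=O)c1cc(C(=O)Nc2ccc3c(c2)CNCC3)cc([N+](=O)[O-])c1)c1ccccc1` gives 710 nM

Compound 2 (11.6 nM) lies within the scatter of compound 1 and far below compound 3 (710 nM). The next compound is compound 4 `COc1ccc(C(CC(=O)O)NC(=O)c2cc(C(=O)Nc3ccc4c(c3)CNCC4)cc([N+](=O)[O-])c2)cc1OC`, which has nitro in place of hydrogen on an aromatic carbon of compound 2: nitro in place of hydrogen on an aromatic carbon is the whole change.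

Among the compounds with values here, no measured step isolates this change. The only one, a 1.5-fold lower number from compound 1 to compound 2 (0.17 log units; within the scatter) for a methoxy, stays within the scatter and bears on it only indirectly. Within the data shown here, compound 3 (710 nM) is the only measured nitro compound, but it also lacks both methoxy groups of compound 2, so its gap cannot be assigned to the nitro alone. A partial share of that gap is assumed.

The expected step is a 6.9-fold higher number from compound 2 to compound 4 (0.84 log units; beyond the scatter) in this assay, towards a weaker inhibitor, with wide uncertainty. The estimate for compound 4 is 80 nM (expected range 15 nM to 400 nM).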

Compound 4, half-maximal inhibitory concentration: 340 nM
Beside the measured number, compound 4's estimate is 4.3-fold (0.63 log units) below it; low and high end bracket the measured number.
By their numbers in this assay, from the lowest: compounds 2 and 1 (each within the scatter of the next); then compound 4; then compound 3.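

In this assay, nitro in place of hydrogen on an aromatic carbon, meta to two large groups, now has a direct reading: a 29-fold higher number from compound 2 to compound 4 (1.47 log units; beyond the scatter), a large step towards a weaker inhibitor. With nitro present, 3,4-dimethoxyphenyl in place of phenyl gives only a modest step, a 2.1-fold lower number from compound 3 to compound 4 (0.32 log units; beyond the scatter), so the weak number of compound 3 lies mostly with the nitro and not with the missing methoxy groups. Nothing at hand bears on why this aromatic carbon tolerates nitro so poorly.

Going by these compounds, it remains open whether the loss belongs to nitro itself or to any group on this carbon; an amine or a nitrile there would separate the two. Also open, on these data alone, is the size of the nitro step with phenyl on the chain, which needs the phenyl compound with hydrogen on this carbon.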